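This account rests on a few compounds, and the source may have more. Where it says the series, first, only, none or still open, it means among the compounds named here.

In an ADME assay on BJ cells (Homo sapiens) for cytotoxicity, read by CellTiter-Glo, with a stated time of 72 h (a higher number here means that more compound is needed for the effect, a lower number that less compound is needed), compound 1 `C[C@@H]1CC[C@H]2CC3C(=O)CC[C@@]31C2(C)C` gives 26000 nM and compound 2 `CC1=C2CC(C)(C)/C=C/C(=O)/C(C)=C\C3=C[C@H](C)C[C@]3(O2)[C@@]1(O)C(F)(F)F` gives 26000 nM as well, which puts compound 2 level with compound 1. These two structures do not differ in just one place, so no single change has yet been tested on its own. Compound 3 `CC1=C2CC(C)(C)/C=C/C(=O)/C(C)=C\C3=C[C@H](C)C[C@]3(O2)[C@]1(C)O` keeps the structure of compound 2 but has methyl in place of trifluoromethyl on a saturated ring carbon, a swap counted as methyl in place of trifluoromethyl on a saturated ring carbon with nothing else altered. Starting from compound 2 at 26000 nM and with no measured step as a guide, no shift beyond the scatter is expected for this swap in this assay when it is run. The estimated step of a 1.0-fold lower number from compound 2 to compound 3 (0.02 log units; within the scatter) stays within that scatter. Compound 3 is expected at an estimated 25000 nM with a likely range of 10000 nM to 50000 nM in repeat measurements.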

Compound 3, half-maximal effective concentration: 26000 nM
For compound 3 the middle estimate is 1.0-fold (0.02 log units) below the measured one, and the stated range covers the measured number.
By their numbers in this assay, from the lowest: compounds 1, 2 and 3 (each within the scatter of the next).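

In this assay, for the compounds shown here, the swap of methyl in place of trifluoromethyl on this saturated ring carbon gives no change at the digits printed from compound 2 to compound 3 (within the scatter), the first comparison here in which only one place differs. At this position, then, the 4 heavy atoms of trifluoromethyl can give way to the 1 heavy atom of methyl without moving the number beyond the scatter, something the earlier pair, with its many differences, could not show. Nothing shown here explains this result.

Going by these compounds, whether this carbon would tolerate a group of another kind, such as an amine, a carboxylic acid or a longer chain, remains open. A single pair in a single assay also cannot show whether the same swap would behave this way on another core.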